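The source may report more compounds than this note shows. Statements on the series, on what has been measured and on what is new or still open speak of the compounds shown alone.

In a functional assay on MCF7 cells (Homo sapiens) for cytotoxicity, read by MTT assay, with a stated time of 96 h (on this read-out higher numbers stand for weaker inhibition and lower numbers for stronger inhibition), compound 2 `COc1cc(C(=O)c2cn(-c3cccc(C)c3)cc2-c2ccc(N)cc2)cc(OC)c1OC` gives 18 nM, the lowest of the two numbers measured here. Among the measured compounds shown here, its only measured neighbour, compound 1 `COc1cc(C(=O)c2cn(-c3cccc(C)c3)cc2-c2ccccc2[N+](=O)[O-])cc(OC)c1OC`, gives 220 nM in this assay, and the one measured step is a 12-fold lower number from compound 1 to compound 2 (1.09 log units; beyond the scatter). That step swapped the group on an aromatic carbon of the shared core. The step to compound 3 `COc1cc(C(=O)c2cn(-c3ccc(F)cc3)cc2-c2ccc(N)cc2)cc(OC)c1OC` is of another kind: 4-fluorophenyl in place of 3-methylphenyl on an aromatic nitrogen. For the measured compounds named here, no measured step touches this position, so the data give no direct guide to its size or direction. Going by the values given here, with nothing pointing either way, and the only change being an exchange of one six-membered aromatic ring of carbon for another of the same size, the expected step is small and within the scatter, a 1.2-fold higher number from compound 2 to compound 3 (0.09 log units; within the scatter). Compound 3 is therefore estimated at 22 nM in this assay, with a range from 8 nM to 65 nM.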

Compound 3, half-maximal inhibitory concentration: 12 nM
For compound 3 the middle estimate is 1.8-fold (0.26 log units) above the measured one, within the range that was stated.
By their numbers in this assay, from the lowest: compounds 3 and 2 (each within the scatter of the next); then compound 1.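

In this assay the group on the aromatic nitrogen now has a measured step of its own, a 1.5-fold lower number from compound 2 to compound 3 (0.18 log units; within the scatter), and it lies within the usual scatter of repeated measurements. At this position, with the 4-aminophenyl group kept in place, 4-fluorophenyl and 3-methylphenyl therefore cannot be told apart, so exchanging one of these aromatic rings for the other leaves the read-out unchanged within the scatter. No measurement is available that could explain this result.

From the compounds shown here alone, whether this position also tolerates something other than a substituted aromatic ring, such as a cyclohexyl ring, an amine or a carboxylic acid, stays open. So do what a plain phenyl group would give here and whether the same exchange would behave alike with the 2-nitrophenyl group of compound 1 in place.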